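The source may hold more compounds than are shown below. What is called first, only, known or untested is meant among the compounds shown, and "the series" means these compounds.

In a functional assay on A-375 cells (Homo sapiens) for antiproliferative activity, read by MTT assay, with a stated time of 48 h (a higher number here means a weaker inhibitor of growth, a lower number a stronger inhibitor of growth), the three measured compounds gave the following:

compound 1 `Cc1ccc(C2=NN(C(=S)Nc3ccccc3)C(c3ccc4c(c3)OCCO4)C2)cc1`: 6320 nM
compound 2 `S=C(Nc1ccccc1)N1N=C(c2ccccc2Br)CC1c1ccc2c(c1)OCCO2`: > 200000 nM, a limit of the assay
compound 3 `S=C(Nc1ccccc1)N1N=C(c2cccc(Cl)c2)CC1c1ccc2c(c1)OCCO2`: > 200000 nM, a limit of the assay

Among the compounds with values here, compound 1 thus stands as the only real number among the three; the two others sit at the limit of > 200000 nM in this assay, at which 2 of the 3 values shown sit. Replacing its 4-methylphenyl gave an at least 31-fold higher number from compound 1 to compound 2 (1.50 log units; beyond the scatter) and an at least 31-fold higher number from compound 1 to compound 3 (1.50 log units; beyond the scatter), both large losses of growth inhibition that ran past the ceiling of the assay. Between compound 2 and compound 3 the two limits leave a step that the two limits leave unreadable from compound 2 to compound 3.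

Compound 4 `S=C(Nc1ccccc1)N1N=C(c2cccs2)CC1c1ccc2c(c1)OCCO2` carries thiophen-2-yl in place of 4-methylphenyl on a carbon with a double bond to nitrogen. Both known exchanges of the 4-methylphenyl on this carbon weakened growth inhibition by a large amount, so a move in the same direction, toward a higher number in this assay, is expected for compound 4, though the thiophen-2-yl is a different kind of ring from the two halogenated phenyls and the size of its step is uncertain. Compound 4 is therefore estimated at 60000 nM, with a likely range from 8000 nM to 200000 nM, which would mean a 9.5-fold higher number from compound 1 to compound 4 (0.98 log units; beyond the scatter).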

Compound 4, concentration for 50% growth inhibition: 121000 nM
Compound 4: the middle estimate sits 2.0-fold (0.30 log units) below what was measured; low and high end bracket the measured number.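

Unlike the two halogenated phenyls, the thiophen-2-yl gives a loss at this position whose size can be read, showing that this five-membered aromatic ring with a sulfur also falls well short of the 4-methylphenyl, with a 19-fold higher number from compound 1 to compound 4 (1.28 log units; beyond the scatter). Against the halogenated phenyls only floors can be given, an at least 1.6-fold lower number from compound 3 to compound 4 (0.21 log units; that floor lies within the scatter) and an at least 1.6-fold lower number from compound 2 to compound 4 (0.21 log units; that floor lies within the scatter), and these floors do not separate compound 4 from compound 2 or compound 3. Compound 2 and compound 3 remain limits of the assay, not numbers: the limit of > 200000 nM in this assay, at which 2 of the 4 values shown sit.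

As far as these compounds go, it remains open whether a 4-methoxyphenyl, a 4-aminophenyl or a pyridin-3-yl on this carbon would keep growth inhibition at the level of compound 1. The compounds shown also leave open whether the methyl group itself matters, or only the ring that carries it.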